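The source may hold more compounds than are shown below. What is called first, only, known or untested is meant among the compounds shown, and "the series" means these compounds.

Working notes on the series, followed in an ADME assay for permeability, using PAMPA, at pH 7.4; a lower number here means that the compound crosses the layer more slowly, a higher number that the compound crosses the layer faster. Compound 1 `CCOC(=O)c1c(-c2cccc(-c3ccccc3)c2)[nH]c2cc(OC)ccc2c1=O` gives 2900 10^-6 cm/s, compound 2 `CCCOc1cccc(-c2[nH]c3cc(OC)ccc3c(=O)c2C(=O)OCC)c1` gives 340 10^-6 cm/s, and compound 3 `CCOC(=O)c1c(-c2cccc(Oc3ccccc3)c2)[nH]c2cc(OC)ccc2c1=O` gives 750 10^-6 cm/s. Compound 3 therefore stands second of the three numbers, lower than compound 1 and higher than compound 2.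

The next structure is compound 4 `CCOC(=O)c1c(-c2cccc(Oc3ccccc3)c2)[nH]c2cc(OC)c(F)cc2c1=O`. Its difference from compound 3 is fluoro in place of hydrogen on an aromatic carbon, ortho to a methoxy group.

For the measured compounds named here, no measured step touches this site. The three available steps exchange phenyl, propoxy and phenoxy groups instead: an 8.5-fold lower number from compound 1 to compound 2 (0.93 log units; beyond the scatter), a 3.9-fold lower number from compound 1 to compound 3 (0.59 log units; beyond the scatter) and a 2.2-fold higher number from compound 2 to compound 3 (0.34 log units; beyond the scatter). They show how far the number has moved for those exchanges, but they give no direction for a fluoro. With no evidence for a direction, no step beyond the scatter is expected in this assay. The estimated step is a 1.1-fold higher number from compound 3 to compound 4 (0.03 log units; within the scatter). For compound 4 the estimated value is 800 10^-6 cm/s, with an expected range of 350 10^-6 cm/s to 1800 10^-6 cm/s.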

Compound 4, apparent permeability: 560 10^-6 cm/s
Compound 4: middle estimate off by 1.4-fold (0.15 log units), on the high side; measured number inside the range.
By their numbers in this assay, from the lowest: compounds 2, 4 and 3 (each within the scatter of the next, the first and the last beyond it); then compound 1.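

With fluoro in place of hydrogen on an aromatic carbon, ortho to a methoxy group, this assay gives a 1.3-fold lower number from compound 3 to compound 4 (0.13 log units; within the scatter), so compound 3 and compound 4 cannot be told apart. This is the only step shown at this site, and unlike the three exchanges among phenyl, propoxy and phenoxy groups, which all lie beyond the scatter, it leaves the number within the scatter. No measurement bearing on the reason for this result is available.

From the compounds shown here alone, whether the same holds for a chloro group, an amine or a carboxylic acid at this position remains open. Also open, going by these compounds, is whether fluoro here would give a similar step with phenyl or propoxy in place of the phenoxy group.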